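Boc Capping of the Pyrrolidine in a Purine Anilide Series

A few compounds are considered here, and "the series" means these few. Any claim that something is new, unique, unknown or untested is made for them only; others in the source may bear on it.

Measured compounds:
compound 1, `CN1CCN(c2ccc(Nc3ncc4nc(Nc5ccccc5)n([C@H]5CCNC5)c4n3)cc2)CC1`, 530 nM
compound 2, `CN1CCN(c2ccc(Nc3ncc4nc(Nc5ccc(F)cc5)n([C@H]5CCNC5)c4n3)cc2)CC1`, 1220 nM

Compound 1 carries a free pyrrolidin-3-yl on the aromatic nitrogen of the shared core. In a functional assay on HCC827 cells (Homo sapiens) for antiproliferative activity, read by MTT assay, with a stated time of 72 h (a higher number here means a weaker inhibitor, a lower number a stronger inhibitor), compound 1 gives 530 nM, the lowest of the two numbers recorded. Within the data shown here, its only neighbour is compound 2, which differs by a fluoro in place of hydrogen on an aromatic carbon and gives 1220 nM; the step of a 2.3-fold higher number from compound 1 to compound 2 (0.36 log units; beyond the scatter) is modest but lies beyond the scatter.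

Compound 3, `CN1CCN(c2ccc(Nc3ncc4nc(Nc5ccccc5)n([C@@H]5CCN(C(=O)OC(C)(C)C)C5)c4n3)cc2)CC1`, has not been measured. It differs from compound 1 by 1-(tert-butoxycarbonyl)pyrrolidin-3-yl in place of pyrrolidin-3-yl on an aromatic nitrogen. Among the measured compounds shown here, no measured step touches this position; the single step recorded concerns the anilino ring and says nothing about the pyrrolidine nitrogen. The estimate therefore rests on compound 1 alone, with a wide range. Compound 3 is expected to give a higher number than compound 1, the step being a 2.8-fold higher number from compound 1 to compound 3 (0.45 log units; beyond the scatter). The estimated value for compound 3 in this assay is 1500 nM, within a range from 400 nM to 6000 nM.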

Compound 3, half-maximal inhibitory concentration: 12 nM
For compound 3 the middle estimate is 130-fold (2.10 log units) above the measured one, and the stated range ends above it.
By their numbers in this assay, from the lowest: compound 3; then compound 1; then compound 2.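

In this assay, the pyrrolidine nitrogen proves a far more sensitive place than the anilino ring: 1-(tert-butoxycarbonyl)pyrrolidin-3-yl in place of pyrrolidin-3-yl on the aromatic nitrogen gives a 44-fold lower number from compound 1 to compound 3 (1.65 log units; beyond the scatter), whereas the fluoro change gave only a 2.3-fold higher number from compound 1 to compound 2 (0.36 log units; beyond the scatter). The earlier compounds shown here both carried the free pyrrolidin-3-yl, so they could not show that this ring need not stay uncapped, or that a substituent with 12 heavy atoms instead of 5 can sit here and give the lowest number of the three. The data shown offer no explanation for the size of this step.

The tert-butoxycarbonyl group changes several things at once, so the compounds shown cannot tell whether the step follows from the carbonyl, the tert-butyl part or the loss of the free ring amine, a question that an acetyl, a methyl or a simple tert-butyl on the pyrrolidine nitrogen, or a cyclopentyl in place of the pyrrolidine, would begin to separate. From the compounds shown here alone, it also remains open whether the para-free anilino preference seen with the fluoro step carries over once the pyrrolidine is capped.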